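Fluoro for ethyl on the fused ring of compound 1

The source may report more compounds than this note shows. Statements on the series, on what has been measured and on what is new or still open speak of the compounds shown alone.

Within the data shown here, compound 1 `CCc1ccc2oc(CSc3nnc(CNc4ccccc4)n3CC)nc2c1` gives 1800 nM in an assay on isolated protein for inhibition of long-chain fatty acid transport protein 1 (Mus musculus) (a higher number here means a weaker inhibitor, a lower number a stronger inhibitor), the only single number in this small set. Compound 2 `CCn1c(CNc2ccccc2)nnc1SCC(=O)Nc1ccc(Cl)cc1` gives > 10000 nM in this assay, which is a limit of the assay and not a number. Compound 3 `CCn1c(CNc2ccccc2)nnc1SCC(=O)Nc1ccc(C(=O)OC)cc1` gives "not determined" (no result reported) in this assay, so no result is available for it. Compound 4 `CCn1c(CNc2ccccc2)nnc1SCc1nc2cc(F)ccc2o1` remains to be measured; it differs from compound 1 by fluoro in place of ethyl on an aromatic carbon. Among the measured compounds shown here, no measured pair differing in one place is available, so the size of this step is unsupported by precedent; in this assay a step no larger than the usual scatter, or slightly beyond it toward weaker inhibition, is expected. For compound 4 the estimate in this assay is 3000 nM, with a range from 1000 nM to 10000 nM. The expected step is a 1.7-fold higher number from compound 1 to compound 4 (0.22 log units; within the scatter).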

Compound 4, half-maximal inhibitory concentration: 7800 nM
Compound 4: the middle estimate sits 2.6-fold (0.41 log units) below what was measured, within the range that was stated.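

Fluoro in place of ethyl is not a neutral change at this aromatic carbon: in this assay the result is a 4.3-fold higher number from compound 1 to compound 4 (0.64 log units; beyond the scatter), so ethyl gives the stronger inhibitor of this pair. Among these compounds, this is the only comparison here that isolates one position on the shared core. Compound 2 gives a limit, not a number: the limit of > 10000 nM in this assay, at which 1 of the 4 values shown sits.

A single step cannot separate the loss of ethyl from the gain of fluoro. From the compounds shown here alone, whether hydrogen, methyl, propyl or methoxy at this carbon would fall nearer compound 1 or compound 4 remains open.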